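The compounds below may be only part of what the source reports. "The series", "measured", "known", "first", "only" and "open" are said of these compounds alone.

Series notes, sulfamate series. Of the compounds shown here, two have numbers so far. Compound 1 `CN(C)CCN(CCN(C)C)c1ccc(C(=O)N2CCc3ccc(OS(N)(=O)=O)cc3C2)cc1` gives 15.9% in an assay on HEK293 cells for inhibition of Steryl-sulfatase (Homo sapiens), tested at 1 uM; on this read-out lower numbers stand for a weaker effect and higher numbers for a stronger effect at the one concentration tested. Compound 2 `CCN(Cc1ccc(Br)cc1)c1ccc(C(=O)N2CCc3ccc(OS(N)(=O)=O)cc3C2)cc1` gives 95.9% in this assay. Going by the values given here, the only step measured so far runs a number 80 percentage points higher from compound 1 to compound 2 (beyond the scatter), with (4-bromobenzyl)(ethyl)amino in place of bis(2-(dimethylamino)ethyl)amino on an aromatic carbon. On the two numbers available, compound 2 stands highest, with compound 1 beyond the scatter below it.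

Compound 3 `CCN(Cc1ccncc1)c1ccc(C(=O)N2CCc3ccc(OS(N)(=O)=O)cc3C2)cc1` is not yet measured. Among the compounds with values here, it differs from compound 2 by pyridin-4-yl in place of 4-bromophenyl on a saturated chain carbon bound to a nitrogen on an aromatic ring, a smaller change than the one from compound 1 to compound 2: the ethyl on the amine nitrogen and the methylene to the ring are kept, only the ring itself is exchanged. Within the data shown here, no measured step exchanges one aromatic ring for another on this chain carbon, so the one step there is bears only loosely on it; it shows that this amine substituent matters a great deal, not how a pyridin-4-yl behaves there. A drop from compound 2 is expected, but a moderate one, estimated at a number 20.9 percentage points lower from compound 2 to compound 3 (beyond the scatter). Compound 3 is therefore expected to give 75% in this assay, within 45% to 95%.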

Compound 3, a percentage reported as inhibition, at one concentration (the size of the read-out at that concentration, not a potency): 86.6%
Compound 3: the middle estimate sits 11.6 percentage points below what was measured; low and high end bracket the measured number.
By their numbers in this assay, from the lowest: compound 1; then compounds 3 and 2 (each within the scatter of the next).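

In this assay the ring on this saturated chain carbon bound to a nitrogen on an aromatic ring can be exchanged with no change beyond the scatter: pyridin-4-yl in place of 4-bromophenyl gives a number 9.3 percentage points lower from compound 2 to compound 3 (within the scatter). Neither the bromine nor a ring of carbon only is therefore required here for a high number at the one concentration tested, which the step between compound 1 and compound 2 could not show, as it exchanged the whole amine substituent. The large difference from bis(2-(dimethylamino)ethyl)amino also holds with ethyl((pyridin-4-yl)methyl)amino, at a number 70.7 percentage points higher from compound 1 to compound 3 (beyond the scatter), so it is now seen with two different rings, while no supporting data explain either step.

The compounds shown leave open whether an aromatic ring is needed on this chain carbon at all, which cyclohexyl or a plain propyl chain in its place would test, and whether the place of the ring nitrogen counts, as pyridin-3-yl would show. The part played by the ethyl on the amine nitrogen is also open, since a methyl or a hydrogen there has no number among these compounds.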